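Swapping a difluorophenyl for a pyridyl on a sulfoxide

The source may hold more compounds than are shown below. What is called first, only, known or untested is meant among the compounds shown, and "the series" means these compounds.

Of the compounds shown here, three built on one shared core have been tested for how much of each a liver-derived cell line tolerates over a long exposure. Compound 1, `CCOC(=O)c1cc2c(CN3CCCC3)c(O)c(OC)cc2nc1C[S+]([O-])c1ccc(F)c(F)c1`, gives 16.5 uM in an ADME assay on HepG2 2.2.15 cells (Homo sapiens) for cytotoxicity, read by MTT assay, with a stated time of 9 days; a lower number here means that less compound is tolerated, a higher number that more compound is tolerated. This is the lowest of the three numbers, meaning compound 1 is the least well tolerated of the set. Compound 2, `CCOC(=O)c1cc2c(Cn3ccnc3C)c(O)c(OC)cc2nc1CSc1ccc(F)cc1`, gives 78.5 uM in this assay, a number beyond the usual scatter above that of compound 1. Compound 3, `CCOC(=O)c1cc2c(Cn3ccnc3)c(O)c(OC)cc2nc1C[S+]([O-])c1cccc(OC)c1`, gives 194 uM in this assay, further above compound 1 again. Compounds 2 and 3 differ from compound 1 in more than one place, so no single change can be tied to these gaps.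

The next compound, compound 4, `CCOC(=O)c1cc2c(CN3CCCC3)c(O)c(OC)cc2nc1C[S+]([O-])c1ccccn1`, differs from compound 1 in one place: pyridin-2-yl in place of 3,4-difluorophenyl on a sulfur. Nothing measured here isolates this kind of swap, so the expectation rests on the general spread among the three compounds. Because compound 1 sits at 16.5 uM with the other two above it, a modest rise in the tolerated concentration is expected for compound 4, though a step within the scatter is as plausible. The step from compound 1 to compound 4 is estimated at a 1.8-fold higher number from compound 1 to compound 4 (0.26 log units; within the scatter). Compound 4 is expected to give about 30 uM, with a range from 10 uM to 90 uM.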

Compound 4, half-maximal toxic concentration: 9.4 uM
For compound 4 the middle estimate is 3.2-fold (0.50 log units) above the measured one; measured number below the stated range.
By their numbers in this assay, from the lowest: compounds 4 and 1 (each within the scatter of the next); then compound 2; then compound 3.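

Among these compounds, compound 1 and compound 4 offer the first comparison in this set that differs in only one place, and in this assay the swap to pyridin-2-yl gives a 1.8-fold lower number from compound 1 to compound 4 (0.24 log units; within the scatter). On a sulfur whose other neighbours are oxygen and a saturated chain carbon, then, this assay does not separate a 3,4-difluorophenyl from a pyridin-2-yl, even though the change removes both fluorines and places a nitrogen in the aromatic ring, which adds one hydrogen-bond acceptor. Nothing measured here offers a reason for this result.

This single pair cannot show whether the same swap would read the same way on compounds that carry different groups elsewhere on the shared core, such as the methylimidazole-type side group of compound 2 or the other side group of compound 3. It also leaves open how this sulfur position would respond to a group of a different kind, such as a small methyl or a saturated cyclohexyl ring, in place of an aromatic ring.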